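Trading butyl for tert-butyl on compound 1

The source may report more compounds than this note shows. Statements on the series, on what has been measured and on what is new or still open speak of the compounds shown alone.

- compound 1 `CCCC[C@@H](O)C(=O)N1C[C@H]2C[C@H]2[C@H]1C(=O)NCc1cc(Cl)ccc1-n1cnnn1` gives 32 mL.min-1.g-1
- compound 2 `CC(C)(C)C[C@@H](O)C(=O)N1[C@@H]2C[C@@H]2C[C@H]1C(=O)NCc1cc(Cl)ccc1-n1cnnn1` gives 71 mL.min-1.g-1

In an ADME assay on liver for metabolic stability, with Liver microsome (Homo sapiens) as the target, read by LC-MS, using microsomes (on this read-out higher numbers stand for fast clearance and lower numbers for slow clearance), compound 1 holds the lower of the two values, clearly apart from compound 2. Compound 3 (`CC(C)(C)[C@@H](O)C(=O)N1C[C@H]2C[C@H]2[C@H]1C(=O)NCc1cc(Cl)ccc1-n1cnnn1`) keeps the core of compound 1 and changes one group (tert-butyl in place of butyl on a saturated chain carbon bound to a carbonyl carbon and an oxygen on a saturated carbon): tert-butyl in place of butyl on a saturated chain carbon bound to a carbonyl carbon and an oxygen on a saturated carbon. Among the compounds with values here, no measured pair shows this change alone, so the expectation is a judgement: a small fall in this assay, toward slower clearance, perhaps not beyond the scatter. The expected step runs a 1.6-fold lower number from compound 1 to compound 3 (0.20 log units; within the scatter) on this read-out. For compound 3 the estimated value is 20 mL.min-1.g-1 with an expected range from 9 mL.min-1.g-1 to 45 mL.min-1.g-1 overall.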

Compound 3, intrinsic clearance in microsomes: 22 mL.min-1.g-1
The estimate for compound 3 lay 1.1-fold (0.04 log units) below the measured number; low and high end bracket the measured number.
By their numbers in this assay, from the lowest: compounds 3 and 1 (each within the scatter of the next); then compound 2.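

In this assay, putting tert-butyl in place of butyl on a saturated chain carbon bound to a carbonyl carbon and an oxygen on a saturated carbon gives a 1.5-fold lower number from compound 1 to compound 3 (0.16 log units; within the scatter). Within the data shown here, this is the first pair here that differs in one place only, and it shows that this position tolerates the swap with no change beyond the usual scatter. No measurement at hand explains the result. From the compounds shown here alone, whether a longer chain, a cyclohexyl ring or an amine at this position would also leave clearance unchanged stays open.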